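Sulfonamide and urea variants on the shared core

This account rests on a few compounds, and the source may have more. Where it says the series, first, only, none or still open, it means among the compounds named here.

Compound 2 `CCNC(=O)NCC1(C(=O)Nc2ccc(-c3ccccc3S(N)(=O)=O)cn2)CC(c2ccc(Cl)c(N)c2)=NO1` carries an ethylcarbamoyl group on the amine nitrogen of the side chain. In an assay on isolated protein for inhibition of serine protease 1 (Homo sapiens) (a lower number here means a stronger inhibitor, a higher number a weaker inhibitor), compound 2 gives only a limit, > 4200 nM. Within the data shown here, compound 1 `Nc1cc(C2=NOC(CNS(=O)(=O)Cc3ccccc3)(C(=O)Nc3ccc(-c4ccccc4S(N)(=O)=O)cn3)C2)ccc1Cl` is the one other member of the series measured so far. In this assay compound 1 likewise gives only a limit, > 4200 nM. The step that the two limits leave unreadable from compound 1 to compound 2 therefore cannot be read, since (the limit of > 4200 nM in this assay, at which 2 of the 2 values shown sit). Compound 3 `Nc1cc(C2=NOC(CNS(=O)(=O)c3cccnc3)(C(=O)Nc3ccc(-c4ccccc4S(N)(=O)=O)cn3)C2)ccc1Cl` differs from compound 2 by (pyridin-3-yl)sulfonyl in place of ethylcarbamoyl on an amine nitrogen. Among the measured compounds shown here, the only step that bears on this change, a step that the two limits leave unreadable from compound 1 to compound 2, has no readable size, so neither a direction nor a size beyond the scatter can be drawn from it. Compound 3 is expected to sit at or near the same limit. For compound 3 the estimated step is a step that the limit leaves unreadable from compound 2 to compound 3. The estimate for compound 3 in this assay is 6000 nM, with a range from 1500 nM to 25000 nM.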

Compound 3, inhibition constant: > 8000 nM
Compound 3 was reported as a limit; the forecaster's own chance of this, stated with the estimate: 70%; middle value at least 1.3-fold (0.12 log units) away from the limit.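

Compound 3 gives only a limit, > 8000 nM, so no step from compound 1 or compound 2 to compound 3 can be read: the limit of > 8000 nM in this assay, at which 1 of the 3 values shown sits.

From the compounds shown here alone, how strongly compound 1, compound 2 and compound 3 inhibit the protease, and whether benzylsulfonyl, ethylcarbamoyl and (pyridin-3-yl)sulfonyl on the amine nitrogen differ at all, stays open.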